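Bromo in Place of Nitro: Expected Change in Cytotoxicity

The source may report more compounds than this note shows. Statements on the series, on what has been measured and on what is new or still open speak of the compounds shown alone.

Measured compounds:
- Compound 1 `CNC(=O)c1cc(Oc2ccc(/C=C/C(=O)c3ccc([N+](=O)[O-])cc3)cc2)ccn1` gives 54300 nM in a functional assay on MCF7 cells (Homo sapiens) for cytotoxicity, read by MTT assay, with a stated time of 72 h; on this read-out higher numbers stand for weaker inhibition and lower numbers for stronger inhibition.
- Compound 2 `CNC(=O)c1cc(Oc2ccc(C(=O)/C=C/c3cccc([N+](=O)[O-])c3)cc2)ccn1` gives only a limit, > 50000 nM, in this assay.
- Compound 3 `CNC(=O)c1cc(Oc2ccc(/C=C/C(=O)c3ccc(Cl)cc3)cc2)ccn1` gives 17500 nM in this assay.

Of the three, compound 2 stands apart in that no number is known for it at all; its result is the limit of the assay (the limit of > 50000 nM in this assay, at which 1 of the 3 values shown sits), so its true value could be anywhere beyond it. Among the compounds with values here, compound 1 and compound 3 form the one measured pair that differ in a single place: a 3.1-fold lower number from compound 1 to compound 3 (0.49 log units; beyond the scatter).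

Compound 4 `CNC(=O)c1cc(Oc2ccc(C(=O)/C=C/c3cccc(Br)c3)cc2)ccn1` differs from compound 2 in the same spirit: bromo in place of nitro on an aromatic carbon, the change sitting on an aromatic carbon of a six-membered aromatic ring of carbon only, meta to a large group. Within the data shown here, the only step that bears on it is the one from compound 1 to compound 3, where a halogen also replaced a nitro group and the number fell by a modest amount beyond the scatter. A step of comparable size and direction is therefore expected here, an at least 2.0-fold lower number from compound 2 to compound 4 (0.30 log units; that floor lies within the scatter), though with the starting point being a limit the footing is loose. Compound 4 is estimated at 25000 nM, likely within 8000 nM to 60000 nM.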

Compound 4, half-maximal inhibitory concentration: 10400 nM
Estimate against measurement, compound 4: 2.4-fold (0.38 log units) above, and the stated range covers the measured number.
By their numbers in this assay, from the lowest: compounds 4 and 3 (each within the scatter of the next); then compound 1.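

Compound 4 shows that replacing a nitro group with a halogen can lower the number on a second core as well, here in the change from 3-nitrophenyl to 3-bromophenyl, and not only in the step of a 3.1-fold lower number from compound 1 to compound 3 (0.49 log units; beyond the scatter): the new step is an at least 4.8-fold lower number from compound 2 to compound 4 (0.68 log units; beyond the scatter). As far as these compounds go, compound 2 gives only a limit, > 50000 nM, so the new step marks a minimum, its true size remains unknown, and it cannot be ranked against the earlier step: the limit of > 50000 nM in this assay, at which 1 of the 4 values shown sits. Compound 4 gives 10400 nM in this assay, so this core now has a measured number at this place on the ring, and later changes there can be compared with an actual value rather than a limit.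

The compounds shown do not tell whether bromo is special on this core or whether chloro would give a similar number, nor how bromo would compare with chloro on the core of compound 3. Also open, from the compounds shown here alone, is what a smaller or very different group at this place, such as fluoro, methoxy, an amine or a carboxylic acid, would do to the number.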